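The source may report more compounds than this note shows. Statements on the series, on what has been measured and on what is new or still open speak of the compounds shown alone.

Measured in a functional assay on RPMI-8226 cells (Homo sapiens) for cytotoxicity, read by MTT assay, with a stated time of 48 h; on this read-out lower numbers stand for stronger inhibition and higher numbers for weaker inhibition:
- Compound 1 `C#CCOC(=O)NN=C1C(Cl)=C(Cl)C(Cl)=C1Cl`: 800 nM
- Compound 2 `O=C(c1ccc(F)cc1)N(N=C1C(Cl)=C(Cl)C(Cl)=C1Cl)C(=O)c1ccc(F)cc1`: 200 nM

Of these two compounds, compound 1 stands higher, at 800 nM. Compound 2 gives 200 nM, and this gap lies beyond the scatter. Compound 3 `C#CC(C)(C)OC(=O)NN=C1C(Cl)=C(Cl)C(Cl)=C1Cl` has not yet been measured in this assay. It departs from compound 1 in a single place: 1,1-dimethylprop-2-yn-1-yl in place of propargyl on an oxygen next to a carbonyl group. In words, it carries 1,1-dimethylprop-2-yn-1-yl in place of propargyl on an oxygen next to a carbonyl group. For the measured compounds named here, no measured pair of compounds differs in one place only, so the data hold no direct guide to this change. A step no larger than the scatter is therefore expected, with neither direction favoured. The expected change is a 1.1-fold lower number from compound 1 to compound 3 (0.06 log units; within the scatter). For compound 3 the estimated value is 700 nM, with an expected range of 250 nM to 2000 nM.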

Compound 3, half-maximal inhibitory concentration: > 5000 nM
Compound 3: no number, only a limit (the forecaster's own chance of this, stated with the estimate: 2%); middle value at least 7.1-fold (0.85 log units) from the limit.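

In this assay, the group on the oxygen next to a carbonyl group proves to matter: 1,1-dimethylprop-2-yn-1-yl in place of propargyl gives an at least 6.2-fold higher number from compound 1 to compound 3 (0.79 log units; beyond the scatter). Compound 3 gives a limit and not a number: the limit of > 5000 nM in this assay, at which 1 of the 3 values shown sits. For the compounds shown here, the triple bond is present in both groups, which go from 3 to 5 heavy atoms, and this is the first comparison in the data that differs in one place only, something compound 1 and compound 2 could not offer.

The compounds shown leave open whether a 1-methylprop-2-yn-1-yl group would give a step of this size. They also leave open whether the triple bond matters at this place at all, a question that a group such as ethyl or benzyl would address.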